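Trimming 2-methylcyclopropyl to cyclopropyl in compound 1

The compounds below may be only part of what the source reports. "The series", "measured", "known", "first", "only" and "open" are said of these compounds alone.

In an ADME assay on microsomes from liver (Rattus norvegicus) for pharmacokinetics (a lower number here means slower removal, a higher number faster removal of the compound), compound 1 `C[C@@H]1C[C@H]1C(=O)N1CCN(c2nc(-c3cnn(C)c3)ncc2C#N)C[C@H]1C` gives the lower of the two actual numbers (54 mL/min/kg). Compound 3 `Cn1cc(-c2ncc(C#N)c(N3C[C@@H]4C[C@H]3CN4c3cccc(F)c3)n2)cn1` gives the other (1090 mL/min/kg). Compound 4 `C[C@@H]1CN(c2nc(-c3cnn(C)c3)ncc2C#N)CCN1C(=O)C1CC1` differs from compound 1 by hydrogen in place of methyl on a saturated ring carbon, so 2-methylcyclopropyl becomes cyclopropyl (hydrogen in place of methyl on a saturated ring carbon). Carrying the cyclopropylcarbonyl of compound 4, compound 2 `Cn1cc(-c2ncc(C#N)c(N3C[C@@H]4C[C@H]3CN4C(=O)C3CC3)n2)cn1` is reported only as a limit (< 36 mL/min/kg). For the measured compounds named here, the one measured step (an at least 30-fold higher number from compound 2 to compound 3 (1.48 log units; beyond the scatter)) is large, but it exchanges the whole cyclopropylcarbonyl for 3-fluorophenyl and removes no lone methyl. The expected step is therefore small and slightly downward (a 1.4-fold lower number from compound 1 to compound 4 (0.13 log units; within the scatter)), staying within the scatter. In this assay compound 4 is estimated at 40 mL/min/kg (expected range 20 mL/min/kg to 75 mL/min/kg).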

Compound 4, clearance: < 36 mL/min/kg
Compound 4 was reported as a limit (the forecaster's own chance of this, stated with the estimate: 35%); middle value at least 1.1-fold (0.04 log units) from the limit.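

In this assay, the step at this saturated ring carbon of the three-membered ring is an at least 1.5-fold lower number from compound 1 to compound 4 (0.17 log units; that floor lies within the scatter). The methyl of compound 1 is therefore not needed for a low number, since the cyclopropyl of compound 4 gives no higher one. Compound 4 is reported only as a limit, which makes this step a floor: the limit of < 36 mL/min/kg in this assay, at which 2 of the 4 values shown sit.

From the compounds shown here alone, whether the true step lies beyond the scatter stays open. Also open, going by these compounds, is how an ethyl group, a hydroxymethyl group or a fluorine atom on this ring carbon would read in this assay.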